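This account rests on a few compounds, and the source may have more. Where it says the series, first, only, none or still open, it means among the compounds named here.

Measured compounds:
Compound 1 `COc1ccc(-c2ccc(-c3ccc(C(=N)N)cc3)s2)cc1` gives 175 nM in a functional assay on MCF7 cells (Homo sapiens) for inhibition, read by sulforhodamine B assay, with a stated time of 48 h; on this read-out higher numbers stand for weaker inhibition of growth and lower numbers for stronger inhibition of growth.
Compound 2 `N=C(N)c1ccc(-c2ccc(-c3cc(Cl)cc(Cl)c3)s2)cc1` gives 193 nM in this assay.
Compound 3 `N=C(N)c1ccc(-c2ccc(-c3ccccc3)s2)cc1F` gives 3170 nM in this assay.

Compound 1 holds the lowest number of the three. Compound 2 lies within the scatter of it, so nothing separates these two on this read-out. Compound 3 stands well apart: its number is higher than that of compound 1 by a margin beyond the scatter. For the measured compounds named here, no pair among the three differs in only one place, so no step from a single structural change has been measured here, and the numbers give no direct guide for a single swap.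

Compound 4 `N=C(N)c1ccc(-c2ccc(-c3ccc(Cl)cc3)s2)cc1` has yet to be measured in this assay. Relative to compound 1 the change is chloro in place of methoxy on an aromatic carbon. Going by the values given here, compound 2, which also carries chloro groups, sits close to compound 1, whereas compound 3, which carries neither methoxy nor chloro and differs in a second place as well, sits far off; no measured pair isolates the effect of this swap on its own. The expected step of a 1.1-fold higher number from compound 1 to compound 4 (0.06 log units; within the scatter) is small, with no direction beyond the scatter committed to. Compound 4 is accordingly estimated at 200 nM, with a range from 80 nM to 500 nM.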

Compound 4, concentration for 50% growth inhibition: 171 nM
Estimate against measurement, compound 4: 1.2-fold (0.07 log units) above; the measured number falls inside the stated range.
By their numbers in this assay, from the lowest: compounds 4, 1 and 2 (each within the scatter of the next); then compound 3.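

Chloro in place of methoxy on an aromatic carbon, para to a large group, gives a 1.0-fold lower number from compound 1 to compound 4 (0.01 log units; within the scatter) in this assay, the only single-place step in the series so far. At this position, the swap removes the oxygen and the hydrogen-bond acceptor counted for methoxy and brings in a single chlorine, yet the read-out does not separate the two compounds, so on this core either group is compatible with a number in the range of compound 1. No measured property of these compounds is available to account for this match.

The compounds shown leave open whether an amine, a carboxylic acid or a longer chain such as butoxy at this position would stay within the scatter of compound 1 or move away from it. Compound 3 also has no partner among them that differs from it in only one place, so its number cannot yet be assigned to any single structural change.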